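The source may report more compounds than this note shows. Statements on the series, on what has been measured and on what is new or still open speak of the compounds shown alone.

Compound 1 `O=C(Nc1cccc(-n2cc(-c3ccncc3)c(-c3ccc(Cl)c(O)c3)n2)c1)Nc1cccc(C(F)(F)F)c1` in a functional assay on NCI/ADR-RES cells (Homo sapiens) for inhibition, read by sulforhodamine B assay, with a stated time of 48 h (on this read-out lower numbers stand for stronger inhibition of growth and higher numbers for weaker inhibition of growth), gives 2140 nM. Within the data shown here, of the three numbers known so far, compound 1 stands second highest. Compound 2 `O=C(Nc1cccc(-n2cc(-c3ccncc3)c(-c3ccc(Cl)c(O)c3)n2)c1)Nc1ccc(Cl)c(Cl)c1` carries 3,4-dichlorophenyl in place of 3-(trifluoromethyl)phenyl on the amide-type nitrogen, and compound 2 gives 2740 nM. That step was a 1.3-fold higher number from compound 1 to compound 2 (0.11 log units; within the scatter). Compound 3 `COc1cc(-c2nn(-c3cccc(NC(=O)Nc4cccc(C(F)(F)F)c4)c3)cc2-c2ccncc2)ccc1Cl` has methyl in place of hydrogen on an oxygen on an aromatic ring, and compound 3 gives 783 nM. That step was a 2.7-fold lower number from compound 1 to compound 3 (0.44 log units; beyond the scatter).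

Compound 4 `O=C(Nc1cccc(-n2cc(-c3ccncc3)c(-c3ccc(Cl)c(O)c3)n2)c1)Nc1cc(C(F)(F)F)cc(C(F)(F)F)c1` differs from compound 1 in one place: trifluoromethyl in place of hydrogen on an aromatic carbon. Among the measured compounds shown here, the one measured step that alters the same aryl on the amide-type nitrogen, from compound 1 to compound 2, stayed within the scatter, so a change on that aryl has not yet moved the number. The step from compound 1 to compound 3 concerns a different part of the molecule and gives no guide here. A number close to that of compound 1 is therefore expected for compound 4, as a step of a 1.1-fold lower number from compound 1 to compound 4 (0.03 log units; within the scatter). The estimate for compound 4 is 2000 nM, with a range from 900 nM to 4500 nM.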

Compound 4, concentration for 50% growth inhibition: 1070 nM
Beside the measured number, compound 4's estimate is 1.9-fold (0.27 log units) above it, within the range that was stated.
By their numbers in this assay, from the lowest: compounds 3, 4, 1 and 2 (each within the scatter of the next, the first and the last beyond it).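

In this assay, trifluoromethyl in place of hydrogen on an aromatic carbon, meta to a trifluoromethyl group, gives a 2.0-fold lower number from compound 1 to compound 4 (0.30 log units; within the scatter). With a 1.3-fold higher number from compound 1 to compound 2 (0.11 log units; within the scatter), there are now two changes on the aryl on the amide-type nitrogen, and neither step lies beyond the scatter, so a second trifluoromethyl at this position, with its 4 heavy atoms, leaves the number of compound 1 within the scatter. No measurement at hand accounts for this result.

The compounds shown leave open whether an amine or a carboxylic acid at this position would give a step beyond the scatter, since only trifluoromethyl and chlorine-bearing aryl variants appear here. They also leave open whether the second trifluoromethyl would behave the same way with methyl on the oxygen, as in compound 3.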